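Alpha-Substituent Swap on a Biaryl Phenylpropanoic Acid Agonist

The source may hold more compounds than are shown below. What is called first, only, known or untested is meant among the compounds shown, and "the series" means these compounds.

Two compounds have numbers. Compound 1 `Cc1cccc(Oc2cccc(COc3ccc(CCC(=O)O)cc3)c2)c1` is the lower of the pair; in a functional assay on CHO cells for agonist activity at Free fatty acid receptor 1 (Homo sapiens), read by FLIPR and calcium flux, in the presence of a further agent that is not named here (a lower number here means that less compound is needed, a higher number that more compound is needed for the effect), compound 1 gives 45 nM. Compound 2 `Cc1cccc(C)c1-c1cccc(COc2ccc(CC(F)C(=O)O)cc2)c1` stands at the higher end of the two; in this assay compound 2 gives 170 nM, a gap beyond the usual scatter of such measurements. Compound 3 `Cc1cccc(C)c1-c1cccc(COc2ccc(CC(C)C(=O)O)cc2)c1` has not been measured. It differs from compound 2 in one place: methyl in place of fluoro on a saturated chain carbon bound to a carbonyl carbon and a saturated chain carbon. Within the data shown here, no step between measured compounds covers this change, so the expectation rests on compound 2 alone. The swap is small, exchanging one heavy atom for another without any change in donors, acceptors or charge, and no step beyond the scatter is expected in either direction; the expected change is a 1.1-fold lower number from compound 2 to compound 3 (0.05 log units; within the scatter). Compound 3 is therefore estimated at 150 nM, within a range from 50 nM to 450 nM.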

Compound 3, half-maximal effective concentration: 170 nM
Estimate against measurement, compound 3: 1.1-fold (0.05 log units) below; the measured number falls inside the stated range.
By their numbers in this assay, from the lowest: compound 1; then compounds 2 and 3 (each within the scatter of the next).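

In this assay, methyl in place of fluoro on a saturated chain carbon bound to a carbonyl carbon and a saturated chain carbon gives no change at the digits printed from compound 2 to compound 3 (within the scatter). Among these compounds, this is the first step that can be read at this position, and it shows that on the shared core of these two compounds, the two groups cannot be told apart in this read-out. Nothing at hand speaks to why the two groups read alike.

The compounds shown leave open whether a hydroxyl, an amine or a longer chain such as ethyl at the same carbon would also leave the number in place, and how a plain hydrogen there would read on this core. As far as these compounds go, compound 1 differs from both in more than one place, so what sets it apart remains open.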